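This account rests on a few compounds, and the source may have more. Where it says the series, first, only, none or still open, it means among the compounds named here.

For the measured compounds named here, in a functional assay on HepG2 cells (Homo sapiens) for antiproliferative activity, read by MTT assay, with a stated time of 48 h (on this read-out lower numbers stand for stronger inhibition and higher numbers for weaker inhibition), compound 1 (`COc1ccc(N(C)c2cc(C)nc(C)n2)cc1`) gives 824 nM and so holds the lower of the two numbers measured so far. Compound 2 (`COc1ccc(N(C)c2cc(C)nc(C)n2)cc1[N+](=O)[O-]`) gives 2990 nM in this assay with a nitro in place of hydrogen on an aromatic carbon. Going by the values given here, the only measured step is a 3.6-fold higher number from compound 1 to compound 2 (0.56 log units; beyond the scatter) and it is modest. Compound 3 (`C[Se]c1ccc(N(C)c2cc(C)nc(C)n2)cc1`) differs from compound 1 elsewhere, at the methoxy: a group of 2 heavy atoms (1 carbon, 1 selenium; no ring) in place of a group of 2 heavy atoms (1 carbon, 1 oxygen; no ring), on an aromatic carbon para to a large group. Among the compounds with values here, no measured compound shows a change at that place, so the nitro step gives no direct guide to size or direction. The expectation therefore starts from compound 1 at 824 nM and assumes no clear shift. The estimated step is a 1.1-fold lower number from compound 1 to compound 3 (0.04 log units; within the scatter) and is expected to stay within the scatter. Compound 3 is expected at 750 nM in this assay with an estimated range from 200 nM to 2800 nM given how little the data show.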

Compound 3, half-maximal inhibitory concentration: 198 nM
Beside the measured number, compound 3's estimate is 3.8-fold (0.58 log units) above it, outside the stated range (below it).
By their numbers in this assay, from the lowest: compound 3; then compound 1; then compound 2.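

Compound 3 shows that the methoxy place is sensitive to change in this assay: replacing it with the group of 1 carbon and 1 selenium gives a lower number (a 4.2-fold lower number from compound 1 to compound 3 (0.62 log units; beyond the scatter)), whereas the nitro change gave a higher one (a 3.6-fold higher number from compound 1 to compound 2 (0.56 log units; beyond the scatter)). The methoxy counts 1 hydrogen-bond acceptor and the entering group counts 0, so a hydrogen-bond acceptor at this place is not required for the activity seen in this pair. The data shown offer no measurement that explains this step.

As far as these compounds go, it remains open whether the lower number is specific to selenium or would also appear with sulfur, as in a methylthio group. Also unresolved is whether a longer chain on the selenium, such as an ethyl group, would keep it.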